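Replacing butyl with (2-carboxyethyl)amino in an antiproliferative series

The compounds below may be only part of what the source reports. "The series", "measured", "known", "first", "only" and "open" are said of these compounds alone.

Measured in a functional assay on PC-3 cells (Homo sapiens) for antiproliferative activity, read by MTT assay, with a stated time of 72 h; on this read-out higher numbers stand for weaker inhibition and lower numbers for stronger inhibition:
- Compound 1 `CCn1c(C(=O)NCCC(=O)OC)ccc1C(CC)(CC)c1ccc(C#CC(O)(CC)CC)c(C)c1`: 36300 nM
- Compound 2 `CCn1c(C(=O)NCc2ccc(OC)cc2)ccc1C(CC)(CC)c1ccc(C#CC(O)(CC)CC)c(C)c1`: > 50000 nM, a limit
- Compound 3 `CCCCC(=O)c1ccc(C(CC)(CC)c2ccc(C#CC(O)(CC)CC)c(C)c2)n1CC`: > 50000 nM, a limit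

Compound 3 stands at a limit and has no exact number. The data cluster at the limit of > 50000 nM in this assay, at which 2 of the 3 values shown sit. Compound 4 `CCn1c(C(=O)NCCC(=O)O)ccc1C(CC)(CC)c1ccc(C#CC(O)(CC)CC)c(C)c1` carries (2-carboxyethyl)amino in place of butyl on a carbonyl carbon. The closest measured change, in which butyl enters, gave an at least 1.3-fold higher number from compound 1 to compound 3 (0.13 log units; that floor lies within the scatter). The other, a step that the two limits leave unreadable from compound 2 to compound 3, adds nothing. Compound 1, which keeps an amide chain, reads 36300 nM. A small move towards a lower number in this assay is therefore expected, possibly none beyond the scatter. The expected change is an at least 1.1-fold lower number from compound 3 to compound 4 (0.04 log units; that floor lies within the scatter). For compound 4 the estimate is 45000 nM, with an expected range of 20000 nM to 60000 nM.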

Compound 4, half-maximal inhibitory concentration: 5130 nM
Compound 4: the middle estimate sits 8.8-fold (0.94 log units) above what was measured; the measured number lies below the stated range.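

In this assay, the carboxylic acid rather than the amide chain alone carries the gain at this position: exchanging only the ester methyl for hydrogen gives a 7.1-fold lower number from compound 1 to compound 4 (0.85 log units; beyond the scatter). Against the butyl ketone, the change gives an at least 9.7-fold lower number from compound 3 to compound 4 (0.98 log units; beyond the scatter), and against the 4-methoxybenzyl amide it gives an at least 9.7-fold lower number from compound 2 to compound 4 (0.98 log units; beyond the scatter). Both of these steps are floors, set by the limits of compound 2 and compound 3: the limit of > 50000 nM in this assay, at which 2 of the 4 values shown sit.

As far as these compounds go, whether the gain depends on the length of the chain that holds the acid remains open. A longer chain ending in a carboxylic acid, or an amine at the chain end, would test this.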